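Core series: hydroxymethylpyridinyl for nitrile on compound 1

The source may hold more compounds than are shown below. What is called first, only, known or untested is meant among the compounds shown, and "the series" means these compounds.

Compound 1 `CCC(CC)CNc1c(C(N)=O)cnc2ccc(C#N)cc12` gives 74 uL/min in an ADME assay on cells (Hepatocyte, Rattus norvegicus) for metabolic stability, with a stated time of 90 min (on this read-out lower numbers stand for slow clearance and higher numbers for fast clearance), the second highest of the three numbers in hand. Its nearest neighbour is compound 2 `NC(=O)c1cnc2ccc(-c3cccnc3)cc2c1NC1CCCC1`, which in this assay gives 65 uL/min, a gap within the scatter; furthest is compound 3 `NC(=O)c1cnc2ccc(-c3cccnc3)cc2c1NCC1CCCCC1`, which gives 130 uL/min, also within the scatter. Going by the values given here, the only single-point step measured so far, a 2.0-fold higher number from compound 2 to compound 3 (0.30 log units; within the scatter), concerns the nitrogen substituent and not the aromatic position changed here.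

Compound 4 `CCC(CC)CNc1c(C(N)=O)cnc2ccc(-c3ccc(CO)nc3)cc12` differs from compound 1 by 6-(hydroxymethyl)pyridin-3-yl in place of cyano on an aromatic carbon. Among the compounds with values here, no measured pair isolates this change. Compounds 2 and 3 carry a six-membered aromatic ring with one hetero atom on the core while compound 1 carries the cyano, and all three numbers lie within the scatter of one another, so the exchange of cyano for a ring of this kind has shown no step beyond the scatter in this set; the hydroxymethyl on the entering ring has no counterpart among the measured compounds.

The number for compound 4 in this assay is therefore expected to sit close to that of compound 1, with a 1.1-fold higher number from compound 1 to compound 4 (0.06 log units; within the scatter) expected to fall within the scatter. Compound 4 is estimated at 85 uL/min, with a likely range from 45 uL/min to 170 uL/min.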

Compound 4, intrinsic clearance in a liver preparation (reported as CLH), per the amount of preparation that the assay uses: > 300 uL/min
Compound 4 ended at the assay's limit; the forecaster's own chance of this, stated with the estimate: 5%; middle value at least 3.5-fold (0.54 log units) away from the limit.
By their numbers in this assay, from the lowest: compounds 2, 1 and 3 (each within the scatter of the next). At a limit, above all of these: compound 4.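

Notes on this position: with the nitrogen substituent of compound 1 held fixed, the exchange of cyano for 6-(hydroxymethyl)pyridin-3-yl on this aromatic carbon of the shared core gives an at least 4.0-fold higher number from compound 1 to compound 4 (0.60 log units; beyond the scatter) in this assay. Going by these compounds alone, this is the first step in the set to lie beyond the scatter, and the first read across this position between two compounds that differ in one place, so the number in this assay does respond to a change at this aromatic carbon. The reading for compound 4 is a limit of the assay and not a number, so the step has a lower bound and no known upper end: the limit of > 300 uL/min in this assay, at which 1 of the 4 values shown sits.

The compounds shown do not separate the entering ring from its hydroxymethyl, since compounds 2 and 3 differ from compound 4 in more than one place, and a plain pyridin-3-yl on the nitrogen substituent of compound 1 would be the pair that isolates it. On these data alone, how a carboxylic acid, a methoxymethyl or an aminomethyl in place of the hydroxymethyl would read in this assay also stays open.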